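Amide swap tested on the bromophenyl analogue

This account rests on a few compounds, and the source may have more. Where it says the series, first, only, none or still open, it means among the compounds named here.

Compound 1 `Nc1sc(-c2ccc(F)cc2)c(-c2ccc(Cl)cc2)c1C(=O)N1CCCC1` carries a pyrrolidin-1-yl group on its carbonyl carbon. In a functional assay on A549 cells (Homo sapiens) for cytotoxicity, read by sulforhodamine B assay, with a stated time of 72 h (a lower number here means a stronger inhibitor, a higher number a weaker inhibitor), compound 1 gives 18800 nM. Compound 2 `Nc1sc(-c2ccc(F)cc2)c(-c2ccc(Cl)cc2)c1C(=O)NCc1ccccc1` differs from it only by benzylamino in place of pyrrolidin-1-yl on a carbonyl carbon; in this assay compound 2 gives 9950 nM, so that a 1.9-fold lower number from compound 1 to compound 2 (0.28 log units; within the scatter). Compound 3 `Nc1sc(-c2ccc(Br)cc2)c(-c2ccc(Cl)cc2)c1C(=O)N1CCCC1` keeps the pyrrolidin-1-yl group but differs from compound 1 by bromo in place of fluoro on an aromatic carbon; in this assay compound 3 gives 7460 nM, which means a 2.5-fold lower number from compound 1 to compound 3 (0.40 log units; beyond the scatter). Compound 4 `Nc1sc(-c2ccc(Br)cc2)c(-c2ccc(Cl)cc2)c1C(=O)NCc1ccccc1` is not yet measured. It differs from compound 3 by benzylamino in place of pyrrolidin-1-yl on a carbonyl carbon, the same change as from compound 1 to compound 2, made at the same place. Going by the values given here, the only guide is that a 1.9-fold lower number from compound 1 to compound 2 (0.28 log units; within the scatter), a step within the scatter. On that basis the step is expected to be a 1.7-fold lower number from compound 3 to compound 4 (0.22 log units; within the scatter). Compound 4 is therefore estimated at 4500 nM, likely between 2000 nM and 10000 nM.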

Compound 4, half-maximal inhibitory concentration: 18700 nM
For compound 4 the middle estimate is 4.2-fold (0.62 log units) below the measured one, and the stated range ends below it.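

On the core of compound 3, benzylamino in place of pyrrolidin-1-yl gives a 2.5-fold higher number from compound 3 to compound 4 (0.40 log units; beyond the scatter) in this assay, so this swap does not carry over unchanged from the core of compound 1: the same change on two cores in this assay, a 1.9-fold lower number (0.28 log units; within the scatter) from compound 1 to compound 2 and a 2.5-fold higher number (0.40 log units; beyond the scatter) from compound 3 to compound 4, 4.7-fold (0.68 log units) apart, beyond the scatter of two such steps. Bromo in place of fluoro does not carry over unchanged either, giving a 1.9-fold higher number from compound 2 to compound 4 (0.27 log units; within the scatter) on the benzylamino core: the same change on two cores in this assay, a 2.5-fold lower number (0.40 log units; beyond the scatter) from compound 1 to compound 3 and a 1.9-fold higher number (0.27 log units; within the scatter) from compound 2 to compound 4, 4.7-fold (0.68 log units) apart, beyond the scatter of two such steps. These four compounds show that the effect of each change depends on the other group present, but they do not show why, or whether this holds on other cores.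

On these data alone, it remains open how other amide groups, such as morpholin-4-yl or ethylamino, would behave on these two cores. As far as these compounds go, it also remains open whether a chloro or methoxy group in place of bromo would follow the same course.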